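Fluorophenyl hydrazide sulfonamides: moving the fluorine from ortho to para

A few compounds are considered here, and "the series" means these few. Any claim that something is new, unique, unknown or untested is made for them only; others in the source may bear on it.

Of the compounds shown here, three have been measured in a functional assay on SGC-7901 cells (Homo sapiens) for antiproliferative activity, read by MTT assay, with a stated time of 24 h; on this read-out lower numbers stand for stronger inhibition and higher numbers for weaker inhibition. Compound 1 `O=C(NNC(=O)c1ccccc1F)c1ccc(NS(=O)(=O)c2cnc(O)nc2O)cc1` reaches only a limit of the assay, > 20000 nM. Compound 2 `O=C(NNC(=O)c1ccc(NS(=O)(=O)c2cnc(O)nc2O)cc1)c1ccc(F)cc1` likewise gives only a limit, > 20000 nM. The change between them is 4-fluorophenyl in place of 2-fluorophenyl on a carbonyl carbon, and the step that the two limits leave unreadable from compound 1 to compound 2 cannot be sized because both values sit at the limit of > 20000 nM in this assay, at which 3 of the 3 values shown sit. Compound 3 `O=C(NNC(=O)c1ccccc1F)c1cccc(NS(=O)(=O)c2cnc(O)nc2O)c1` also stops at a limit, > 20000 nM; how its core differs from that of compound 1 is not broken down here.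

Compound 4 `O=C(NNC(=O)c1cccc(NS(=O)(=O)c2cnc(O)nc2O)c1)c1ccc(F)cc1` has not yet been measured in this assay. It differs from compound 3 by 4-fluorophenyl in place of 2-fluorophenyl on a carbonyl carbon, the same change as that from compound 1 to compound 2, at the same place. Since every value shown so far rests at the limit of > 20000 nM in this assay, at which 3 of the 3 values shown sit, the expected step in this assay is a step that the limit leaves unreadable from compound 3 to compound 4, which is to say no readable movement. For compound 4 the estimate in this assay is 30000 nM, between 15000 nM and 100000 nM, most likely reported again only as a limit.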

Compound 4, half-maximal inhibitory concentration: > 20000 nM
Compound 4: no number, only a limit; the forecaster's own chance of this, stated with the estimate: 85%; the middle value is on the limit's open side.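

No new step can be read from compound 3 to compound 4 in this assay, because the result for compound 4 is again only a limit and not a number: the limit of > 20000 nM in this assay, at which 4 of the 4 values shown sit.

As far as these compounds go, whether 4-fluorophenyl in place of 2-fluorophenyl changes antiproliferative activity at all, and how the four compounds rank, stays open.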